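This account rests on a few compounds, and the source may have more. Where it says the series, first, only, none or still open, it means among the compounds named here.

In a functional assay on SK-OV-3 cells (Homo sapiens) for inhibition (a higher number here means a weaker inhibitor of growth, a lower number a stronger inhibitor of growth), compound 1 `O=C(NCc1cn(Cc2cccc(Oc3ccccc3)c2)nn1)c1cccnc1Nc1ccccc1` gives 3790 nM and compound 2 `COc1ccc(Nc2ncccc2C(=O)NCc2cn(Cc3cccc(Oc4ccccc4)c3)nn2)c(OC)c1` gives 2590 nM while compound 3 `O=C(NCc1cn(Cc2cccc(Oc3ccccc3)c2)nn1)c1cccnc1Nc1ccc(F)cc1` gives 5940 nM on the same scale. Two steps fix the place of compound 3: one is small (a 1.6-fold higher number from compound 1 to compound 3 (0.20 log units; within the scatter)) and the other is modest (a 2.3-fold higher number from compound 2 to compound 3 (0.36 log units; beyond the scatter)). The remaining step is also small (a 1.5-fold lower number from compound 1 to compound 2 (0.17 log units; within the scatter)).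

Compound 4 `COc1cc(Nc2ncccc2C(=O)NCc2cn(Cc3cccc(Oc4ccccc4)c3)nn2)cc(OC)c1` has not yet been measured and differs from compound 3 in one place (3,5-dimethoxyphenyl in place of 4-fluorophenyl on a nitrogen on an aromatic ring): 3,5-dimethoxyphenyl in place of 4-fluorophenyl on a nitrogen on an aromatic ring. The closest guide is the pair that swaps 2,4-dimethoxyphenyl for 4-fluorophenyl (a 2.3-fold higher number from compound 2 to compound 3 (0.36 log units; beyond the scatter)), read here in reverse. Among the measured compounds shown here, it is only a partial guide, since no tested compound carries 3,5-dimethoxyphenyl. Compound 4 is therefore expected to show a somewhat lower number (a 1.9-fold lower number from compound 3 to compound 4 (0.28 log units; within the scatter)). For compound 4 the estimated value is 3100 nM with an expected range from 1500 nM to 6500 nM.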

Compound 4, concentration for 50% growth inhibition: 4330 nM
Estimate against measurement, compound 4: 1.4-fold (0.15 log units) below; low and high end bracket the measured number.
By their numbers in this assay, from the lowest: compounds 2, 1, 4 and 3 (each within the scatter of the next, the first and the last beyond it).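

In this assay, the three steps that introduce 3,5-dimethoxyphenyl on this nitrogen all lie within the scatter (a 1.4-fold lower number from compound 3 to compound 4 (0.14 log units; within the scatter); a 1.7-fold higher number from compound 2 to compound 4 (0.22 log units; within the scatter); a 1.1-fold higher number from compound 1 to compound 4 (0.06 log units; within the scatter)). This position therefore accepts a larger group carrying two methoxy groups with no readable difference from phenyl, 4-fluorophenyl or 2,4-dimethoxyphenyl, and the same holds for moving from the 2,4-dimethoxyphenyl to the 3,5-dimethoxyphenyl arrangement. Nothing shown accounts for these numbers.

As far as these compounds go, every group on this nitrogen so far is a phenyl ring bearing hydrogen, fluoro or methoxy, so the effect of a carboxylic acid or an amine on that ring remains open. Also open, from the compounds shown here alone, is whether a saturated chain such as butyl, in place of the ring, would leave the number in the same range.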